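Carbamoyl replacing the aryloxypropyl chain on the ring oxygen

The compounds below may be only part of what the source reports. "The series", "measured", "known", "first", "only" and "open" are said of these compounds alone.

Compound 3 `COc1ccc(OCCCOc2cc(=O)n(CCCO)c3c2CC(C/C=C(\C)CCC=C(C)C)C(C)(C)C3)cc1` gives 0% in a functional assay on PANC-1 cells (Homo sapiens) for inhibition, read by MTT assay, with a stated time of 24 h, tested at 10 uM (on this read-out higher numbers stand for more inhibition at the one concentration tested (going by the name of the read-out) and lower numbers for less inhibition), the lowest of the three numbers in hand. Compound 1 `COc1ccc(C(=O)NCCCOc2cc(=O)n(CCCO)c3c2CC(C/C=C(\C)CCC=C(C)C)C(C)(C)C3)cc1` gives 14.1% and compound 2 `CC(C)=CCC/C(C)=C/CC1Cc2c(OCCCNC(=O)c3ccc([N+](=O)[O-])cc3)cc(=O)n(CCCO)c2CC1(C)C` gives 6.5%. The step of a number 14.1 percentage points lower from compound 1 to compound 3 (beyond the scatter) is beyond the scatter; the steps of a number 6.5 percentage points lower from compound 2 to compound 3 (within the scatter) and a number 7.6 percentage points lower from compound 1 to compound 2 (within the scatter) are within it, so compound 3 is separated cleanly only from compound 1.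

Compound 4 `CC(C)=CCC/C(C)=C/CC1Cc2c(OC(=O)Nc3ccc(F)c(Cl)c3)cc(=O)n(CCCO)c2CC1(C)C` is the next compound. The change (3-chloro-4-fluorophenyl)carbamoyl in place of 3-(4-methoxyphenoxy)propyl on an oxygen on an aromatic ring takes away the whole 3-(4-methoxyphenoxy)propyl chain and places the (3-chloro-4-fluorophenyl)carbamoyl directly on the oxygen on the aromatic ring. Of the measured steps, those from compound 1 and compound 2 to compound 3 bear on it most nearly, since both exchange the substituent held on that same oxygen; the two chains carrying a carbonyl-linked nitrogen gave the higher numbers, the ether chain the lowest. Among the measured compounds shown here, no measured step removes the three-carbon chain itself, so the size for compound 4 is uncertain. A small rise from compound 3 is expected, a number 12 percentage points higher from compound 3 to compound 4 (beyond the scatter), still not clearly beyond the scatter. Compound 4 is therefore estimated at 12%, within the range 0% to 35%.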

Compound 4, a percentage reported as inhibition, at one concentration (the size of the read-out at that concentration, not a potency): 0%
Compound 4: middle estimate off by 12 percentage points, on the high side; low and high end bracket the measured number.
By their numbers in this assay, from the lowest: compounds 3, 4, 2 and 1 (each within the scatter of the next, the first and the last beyond it).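

Across this assay, putting (3-chloro-4-fluorophenyl)carbamoyl directly on the oxygen on an aromatic ring in place of 3-(4-methoxyphenoxy)propyl gives no change at the digits printed from compound 3 to compound 4 (within the scatter). Among the compounds shown here, this is the first measured step at this position that removes the propyl chain rather than exchanging what the chain carries, and the carbamoyl link with its amide hydrogen and halogenated phenyl ring does not separate the new compound from the ether chain in this read-out. No measurement shown accounts for this flat step, and with both compounds reading the same at the one concentration tested, the read-out gives no size for the effect of either group.

On these data alone, it remains open whether the same (3-chloro-4-fluorophenyl)carbamoyl would read differently when held on a propyl chain, or whether a carbamoyl bearing a plain phenyl or a 4-methoxyphenyl ring would differ from the halogenated one. A terminal amine or a carboxylic acid on a propyl chain at this oxygen, or a longer chain there, would test how far this position responds at all in this assay.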